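This account rests on a few compounds, and the source may have more. Where it says the series, first, only, none or still open, it means among the compounds named here.

Working notes on the series built on the shared core of compound 1 `Nc1sc2cnccc2c1C(=O)c1ccccc1`. In an assay on CHO cells for displacement of a labelled ligand from adenosine receptor A1 (Homo sapiens), tested at 10 uM (a lower number here means less inhibition, a higher number more inhibition at the concentration tested (going by the name of the read-out)), compound 1 gives 0%. Compound 2 `Nc1sc2cnccc2c1C(=O)c1ccccc1Cl` gives 0% in this assay, and compound 3 `Nc1sc2cnccc2c1C(=O)c1cccc(C(F)(F)F)c1` gives 0%. Compound 1 therefore stands level with compounds 2 and 3 at the digits shown; compound 2 is the nearest and compound 3 the furthest, and both gaps lie within the scatter.

Two measured steps start from compound 1. With chloro in place of hydrogen on an aromatic carbon the result is no change at the digits printed from compound 1 to compound 2 (within the scatter); with trifluoromethyl in place of hydrogen on an aromatic carbon the result is no change at the digits printed from compound 1 to compound 3 (within the scatter). Neither change on the phenyl moved the read-out.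

Compound 4 `Nc1sc2cnccc2c1C(=O)c1cccs1` differs from compound 1 by thiophen-2-yl in place of phenyl on a carbonyl carbon. Both measured steps bear on this change, since each alters the same phenyl attached to the carbonyl carbon, and each stayed within the scatter. A whole-ring swap is a larger change than either, but nothing in the measured compounds points in any direction, so no step beyond the scatter is expected in this assay. Compound 4 is expected to give 0%, with a range from -10% to 12%. This estimate means an expected step of no change at the digits printed from compound 1 to compound 4 (within the scatter).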

Compound 4, a percentage reported as inhibition, at one concentration (the size of the read-out at that concentration, not a potency): 35%
Beside the measured number, compound 4's estimate is 35 percentage points below it; measured number above the stated range.
By their numbers in this assay, from the lowest: compounds 1, 2 and 3 (each within the scatter of the next); then compound 4.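

In this assay, the group on the carbonyl carbon proves able to move the read-out: thiophen-2-yl in place of phenyl gives a number 35 percentage points higher from compound 1 to compound 4 (beyond the scatter). The flat result across compound 1, compound 2 and compound 3 therefore holds only for chloro and trifluoromethyl on the phenyl, and does not extend to replacing the ring itself. The entering ring differs from the one leaving in ring size, in its sulfur and in its counted hydrogen-bond acceptor, but no measurement is available that separates these differences or explains the step.

As far as these compounds go, whether the gain is particular to thiophen-2-yl remains open, and thiophen-3-yl, furan-2-yl or pyridin-2-yl on the same carbonyl carbon, or a methyl group on the thiophene ring, would bear on that question. Also open, from the compounds shown here alone, is how far the read-out depends on the rest of the shared core, including its amine, and whether an acetamide in place of that amine would keep the gain seen with compound 4.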